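The compounds below may be only part of what the source reports. "The series", "measured", "known", "first", "only" and "open" are said of these compounds alone.

Measured so far:
compound 1, `Cc1cc(-c2ccsc2)cn2c(CSCCc3ccccc3)cnc12`: >= 4 ug/mL
compound 2, `COc1cccc(-c2cc(C)cn3c(CSCCc4ccccc4)cnc23)c1`: 100 ug/mL

In an ADME assay on HEL cells (Homo sapiens) for cytotoxicity, with a stated time of 3 days (on this read-out lower numbers stand for higher toxicity in this test and higher numbers for lower toxicity in this test), compound 1 gives >= 4 ug/mL, and this value is a limit of the test rather than a number. In this assay compound 2 gives 100 ug/mL. Among the compounds with values here, no step between these two compounds has been worked out, so the pair shows only that compound 2 sits at a high number and compound 1 at a limit, which is the point noted in the limit of >= 4 ug/mL in this assay, at which 1 of the 2 values shown sits.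

Compound 3, `Cc1cc(-c2ccc(C#N)cc2)cn2c(CSCCc3ccccc3)cnc12`, is not yet measured. It differs from compound 1 in one place: 4-cyanophenyl in place of thiophen-3-yl on an aromatic carbon. With compound 1 known only as a limit, the size of the step in this assay cannot be read from the data; a move toward higher numbers, past the usual scatter, seems the more likely outcome, but a result close to the limit cannot be excluded. Compound 3 is expected to give about 20 ug/mL, within the range 4 ug/mL to 100 ug/mL. That estimate means an expected step that the limit leaves unreadable from compound 1 to compound 3.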

Compound 3, minimum cytotoxic concentration: >= 20 ug/mL
Compound 3: a limit, no number (the forecaster's own chance of this, stated with the estimate: 40%); the middle value lies on the limit itself.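

In this assay, within the data shown here, compound 1 and compound 3 are both known only as limits and not as numbers, so no step between them can be read. The compounds shown leave open whether 4-cyanophenyl in place of thiophen-3-yl shifts the minimum cytotoxic concentration at all, and in which direction.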